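Phenoxy to benzyl on the anilide carbon: expected step

The source may report more compounds than this note shows. Statements on the series, on what has been measured and on what is new or still open speak of the compounds shown alone.

Compound 1 `CC1CCN(C(=O)c2cccc(N/C(=N/O)c3ccc4occc4c3)c2)CC1` and compound 2 `O/N=C(/Nc1cccc(Oc2ccccc2)c1)c1ccc2occc2c1` share one core and differ at a single aromatic carbon. In an assay on isolated protein for inhibition of Indoleamine 2,3-dioxygenase 1 (Homo sapiens), read by spectrophotometry (a higher number here means a weaker inhibitor, a lower number a stronger inhibitor), compound 1 gives > 30000 nM, which is a limit of the assay and not a number. In this assay compound 2 gives > 30000 nM, likewise a limit. Among the measured compounds shown here, the only measured step, a step that the two limits leave unreadable from compound 1 to compound 2, is therefore unreadable in size and direction; the whole evidence on the series is the limit of > 30000 nM in this assay, at which 2 of the 2 values shown sit. Compound 2 thus stands at the limit, with nothing to rank it against.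

Compound 3 `O/N=C(/Nc1cccc(Cc2ccccc2)c1)c1ccc2occc2c1` differs from compound 2 by benzyl in place of phenoxy on an aromatic carbon. No measured step bears on this change, and the one step shown gives no size to carry over. Compound 3 is expected to give 40000 nM in this assay, within 8000 nM to 200000 nM, most probably again reported only as a limit. The expected step that the limit leaves unreadable from compound 2 to compound 3 is none beyond the scatter.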

Compound 3, half-maximal inhibitory concentration: > 30000 nM
Compound 3: only a limit was reported; the forecaster's own chance of this, stated with the estimate: 80%; the middle value lies beyond the limit too.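

In this assay compound 3 gives > 30000 nM, a limit and not a number. Its steps from compound 1 and compound 2 therefore cannot be read. The compounds shown leave open whether any group at this aromatic carbon on the shared core gives a readable number in this assay.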